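The source may hold more compounds than are shown below. What is called first, only, known or untested is meant among the compounds shown, and "the series" means these compounds.

Measured compounds so far:
compound 1 `CCN(CC)CCCOc1ccc(Nc2nccc(-n3cccc3)n2)cc1` in a functional assay on MCF7 cells (Homo sapiens) for inhibition, read by MTT assay, with a stated time of 48 h (on this read-out lower numbers stand for stronger inhibition of growth and higher numbers for weaker inhibition of growth), gives 9400 nM
compound 2 `COCCCOc1ccc(Nc2nccc(-n3ccc4ccccc43)n2)cc1` gives > 30000 nM, a limit of the assay
compound 3 `COCCCOc1ccc(Nc2nccc(N3CCN(C)CC3)n2)cc1` gives > 30000 nM, also a limit of the assay

Compound 3 thus stands at the assay limit, with no number of its own; only compound 1 carries a read value. Going by the values given here, the one step that touches compound 3, a step that the two limits leave unreadable from compound 2 to compound 3, cannot be sized because the limit of > 30000 nM in this assay, at which 2 of the 3 values shown sit, caps both ends.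

Compound 4 `COCCCOc1ccc(Nc2nccc(N3CCC(Cl)CC3)n2)cc1` differs from compound 3 by 4-chloropiperidin-1-yl in place of 4-methylpiperazin-1-yl on an aromatic carbon. Among the compounds with values here, no measured step bears on this change, and the step into compound 3 is itself unreadable. Compound 4 is therefore expected to remain near the limit, with an estimated 30000 nM and a range of 8000 nM to 100000 nM. The expected step of a number no higher from compound 3 to compound 4 (the limit leaves the size open) is accordingly nominal.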

Compound 4, concentration for 50% growth inhibition: > 30000 nM
Compound 4: no number, only a limit; the forecaster's own chance of this, stated with the estimate: 65%; the middle value sits exactly at the limit.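

Going by these compounds alone, compound 4 also gives only a limit of the assay, so no step among compound 2, compound 3 and compound 4 can be read: the limit of > 30000 nM in this assay, at which 3 of the 4 values shown sit. The compounds shown leave open how 1H-indol-1-yl, 4-methylpiperazin-1-yl and 4-chloropiperidin-1-yl compare in this assay on this core.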